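The source may hold more compounds than are shown below. What is called first, only, known or untested is meant among the compounds shown, and "the series" means these compounds.

Measured in an assay on isolated protein for displacement of a labelled ligand from metabotropic glutamate receptor 5 (Homo sapiens), with a stated time of 60 min, tested at 1 uM; on this read-out higher numbers stand for more inhibition at the one concentration tested (going by the name of the read-out) and lower numbers for less inhibition:
compound 1 `CC1CCN(c2c(S(=O)(=O)c3cc(Cl)cc(Cl)c3)cnc3cc(F)ccc23)CC1` gives 87%
compound 2 `CC1CCN(c2c(S(=O)(=O)c3ccc(F)cc3)cnc3cc(F)ccc23)CC1` gives 74.5%
compound 3 `CC1CCN(c2c(S(=O)(=O)c3ccc(F)cc3)cnc3cc(Cl)ccc23)CC1` gives 91%

Compound 4 `CC1CCN(c2c(S(=O)(=O)c3cc(Cl)cc(Cl)c3)cnc3cc(Cl)ccc23)CC1` is not yet measured. It differs from compound 3 by 3,5-dichlorophenyl in place of 4-fluorophenyl on a sulfonyl sulfur. The same change is made from compound 2 to compound 1, by 3,5-dichlorophenyl in place of 4-fluorophenyl on a sulfonyl sulfur, and there it gave a number 12.5 percentage points higher from compound 2 to compound 1 (beyond the scatter). The cores of compound 2 and compound 3 differ by chloro in place of fluoro on an aromatic carbon, a change that on its own gave a number 16.5 percentage points higher from compound 2 to compound 3 (beyond the scatter). Compound 3 and compound 1 lie within the scatter of each other; both stand beyond compound 2.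

The step from compound 3 to compound 4 is expected to be smaller than the earlier one, estimated at a number 2 percentage points higher from compound 3 to compound 4 (within the scatter), because compound 3 already gives 91% and the read-out has little room left above it. Compound 4 is expected to give 93%, estimated between 84% and 99%.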

Compound 4, a percentage reported as inhibition, at one concentration (the size of the read-out at that concentration, not a potency): 93%
For compound 4 middle estimate and measured number coincide at the digits printed; low and high end bracket the measured number.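

In this assay 3,5-dichlorophenyl in place of 4-fluorophenyl on a sulfonyl sulfur gives a number 2 percentage points higher from compound 3 to compound 4 (within the scatter) and the two readings of this change do not differ: the same change on two cores in this assay, a number 12.5 percentage points higher (beyond the scatter) from compound 2 to compound 1 and a number 2 percentage points higher (within the scatter) from compound 3 to compound 4, 10.5 percentage points apart, within the scatter of two such steps.
Chloro in place of fluoro on an aromatic carbon gives a number 6 percentage points higher from compound 1 to compound 4 (within the scatter) and its two readings do not differ either: the same change on two cores in this assay, a number 16.5 percentage points higher (beyond the scatter) from compound 2 to compound 3 and a number 6 percentage points higher (within the scatter) from compound 1 to compound 4, 10.5 percentage points apart, within the scatter of two such steps.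
Each change thus carries between these two cores without a difference that can be resolved, but two cores and one concentration do not show that the step keeps its size, and they give no potency.

The compounds shown leave open whether an amine or a carboxylic acid in place of the chloro or fluoro groups would hold the read-out. As far as these compounds go, how compound 4 and its neighbours separate at lower concentrations also remains open.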